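A few compounds are considered here, and "the series" means these few. Any claim that something is new, unique, unknown or untested is made for them only; others in the source may bear on it.

Three compounds share one core and differ in the group carried on the saturated chain carbon bound to the amine nitrogen. In a functional assay on BE(2)-C cells (Homo sapiens) for inhibition, read by MTT assay, with a stated time of 72 h (on this read-out lower numbers stand for stronger inhibition of growth and higher numbers for weaker inhibition of growth), compound 1 `O=S(=O)(NCCCNCc1ccccc1Cl)c1cc(C(F)(F)F)cc(C(F)(F)F)c1` gives 15000 nM. Compound 2 `O=S(=O)(NCCCNCC1COc2ccccc2O1)c1cc(C(F)(F)F)cc(C(F)(F)F)c1` gives 2800 nM, and compound 3 `O=S(=O)(NCCCNCc1ccc(C(F)(F)F)cc1)c1cc(C(F)(F)F)cc(C(F)(F)F)c1` gives 2700 nM. Going by the values given here, compound 3 has the lowest number of the three, but its gap to compound 2 is within the scatter a 1.0-fold lower number from compound 2 to compound 3 (0.02 log units; within the scatter); only the step of a 5.6-fold lower number from compound 1 to compound 3 (0.74 log units; beyond the scatter) is beyond it. Compound 4 `O=S(=O)(NCCCNCc1ccccc1)c1cc(C(F)(F)F)cc(C(F)(F)F)c1` carries hydrogen in place of trifluoromethyl on an aromatic carbon. Among the compounds with values here, no measured step removes a group from this ring; the steps of a 5.4-fold lower number from compound 1 to compound 2 (0.73 log units; beyond the scatter) and a 5.6-fold lower number from compound 1 to compound 3 (0.74 log units; beyond the scatter) swap whole ring groups. A small step toward a higher number, or none beyond the scatter, is expected: a 1.9-fold higher number from compound 3 to compound 4 (0.27 log units; within the scatter). Compound 4 is estimated at 5000 nM, between 2000 nM and 15000 nM.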

Compound 4, concentration for 50% growth inhibition: 12000 nM
For compound 4 the middle estimate is 2.4-fold (0.38 log units) below the measured one; the range from low to high includes it.
By their numbers in this assay, from the lowest: compounds 3 and 2 (each within the scatter of the next); then compounds 4 and 1 (each within the scatter of the next).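

Taking the trifluoromethyl off is a real loss: a 4.4-fold higher number from compound 3 to compound 4 (0.65 log units; beyond the scatter) shows that the benzyl group alone does not match the 4-(trifluoromethyl)benzyl group. The plain phenyl also falls apart from the group on compound 2, with a 4.3-fold higher number from compound 2 to compound 4 (0.63 log units; beyond the scatter), while a 1.3-fold lower number from compound 1 to compound 4 (0.10 log units; within the scatter) means chloro and hydrogen on the ring cannot be told apart here. Nothing measured here gives a reason for these steps. As far as these compounds go, whether a nitrile, an amine or a carboxylic acid in place of the trifluoromethyl would match compound 3 stays open, as does the result of a longer chain in the shared core.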